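The compounds below may be only part of what the source reports. "The series", "measured", "known", "first", "only" and "open" are said of these compounds alone.

In a functional assay on NUGC-3 cells (Homo sapiens) for inhibition, read by sulforhodamine B assay, with a stated time of 48 h (on this read-out lower numbers stand for stronger inhibition of growth and higher numbers for weaker inhibition of growth), compound 1 `O=C(Nc1cccc(O)c1)C1c2ccccc2CCN1C(=O)c1ccc(Cl)cc1` gives > 10000 nM, which is a limit of the assay rather than a measured number. Two further compounds share this outcome. Compound 2 `COc1ccccc1NC(=O)c1nccc2ccccc12` gives > 10000 nM in this assay, again a limit. Compound 3 `COc1ccc(NC(=O)C2NCCc3ccccc32)cc1` gives > 10000 nM in this assay, also a limit. Compound 1 therefore stands where every value stands, at the limit of > 10000 nM in this assay, at which 3 of the 3 values shown sit. Going by the values given here, no two of these three compounds differ in only one place, so no measured step between them can be drawn, and the numbers give no direction in which any change has moved growth inhibition.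

Compound 4 `O=C(Nc1ccccc1C(F)(F)F)C1c2ccccc2CCN1C(=O)c1ccc(Cl)cc1` has not yet been measured. It differs from compound 1 by 2-(trifluoromethyl)phenyl in place of 3-hydroxyphenyl on an amide-type nitrogen. The 3-hydroxyphenyl leaves with its hydrogen-bond donor and acceptor, and the entering 2-(trifluoromethyl)phenyl brings none of either. Since all measured values sit at the limit, there is nothing that shows whether a change on this amide-type nitrogen strengthens or weakens inhibition. The expected step is a number no higher from compound 1 to compound 4 (the limit leaves the size open), that is, nothing beyond the usual scatter. Compound 4 is estimated at 10000 nM, in a range from 3000 nM to 30000 nM, with a good chance that this assay again reports only a limit.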

Compound 4, concentration for 50% growth inhibition: > 10000 nM
Compound 4: no number, only a limit; the forecaster's own chance of this, stated with the estimate: 75%; the middle value lies on the limit itself.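

In this assay compound 4 gives > 10000 nM, which is a limit and not a number. Compound 1 also sits at a limit, so no step can be read between compound 1 and compound 4. What the compounds shown leave open is which structural change, if any, would yield a measurable growth inhibition, because every result stands at one place: the limit of > 10000 nM in this assay, at which 4 of the 4 values shown sit.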